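Aryl swap on the shared core: compound 3 to compound 4

The source may hold more compounds than are shown below. What is called first, only, known or untested is meant among the compounds shown, and "the series" means these compounds.

In a functional assay on HL-60 cells (Homo sapiens) for activation, read by flow cytometry, with a stated time of 4 days (on this read-out lower numbers stand for an effect already at smaller amounts and higher numbers for an effect only at larger amounts of compound), only compound 3 `Cc1cccc(C)c1-c1cc2c(cn1)ncn2-c1ccc(OC(F)F)cc1` gives a number, 980 nM. Compound 1 `COc1ccc(-n2cnc3cnc(-c4cccc(NC(C)=O)c4)cc32)cc1OC` reaches only a limit in this assay, > 30000 nM. Compound 2 `Cc1cc(F)ccc1-c1cc2c(cn1)ncn2-c1ccc(O)nc1` likewise reaches only a limit in this assay, > 10000 nM. For the measured compounds named here, compound 1 and compound 2 differ from compound 3 in more than one place, so no single step is measured in this assay. Compound 4 `Cc1cc(F)c(F)cc1-c1cc2c(cn1)ncn2-c1ccc(OC(F)F)cc1` is the next variant: 4,5-difluoro-2-methylphenyl in place of 2,6-dimethylphenyl on an aromatic carbon. The shared core of compound 3 is kept and only the aryl group on the aromatic carbon is altered. Going by the values given here, with no measured step of this kind, a step of modest size, if any, is expected in this assay, possibly within the scatter. Compound 4 is estimated at 1500 nM, range 500 nM to 5000 nM, in this assay. The expected step of a 1.5-fold higher number from compound 3 to compound 4 (0.18 log units; within the scatter) is toward a weaker effect, near the edge of the scatter.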

Compound 4, half-maximal effective concentration: 220 nM
Compound 4: the middle estimate sits 6.8-fold (0.83 log units) above what was measured, and the stated range ends above it.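

For the compounds shown here, this is the first single-place step: in this assay 4,5-difluoro-2-methylphenyl in place of 2,6-dimethylphenyl gives a 4.5-fold lower number from compound 3 to compound 4 (0.65 log units; beyond the scatter) on the shared core. The aryl group at this position therefore moves the read-out, and the change favours an effect at smaller amounts, though this rests on one pair only. Nothing shown bears on the cause of this step.

Going by these compounds, whether the fluorine atoms or the change in methyl groups carries the step stays open. Also open, on these data alone, is how an amine or a carboxylic acid on this aryl ring would read in this assay when set against compound 4.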